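Swapping the amine tail on the sulfamate series

A few compounds are considered here, and "the series" means these few. Any claim that something is new, unique, unknown or untested is made for them only; others in the source may bear on it.

Of the compounds shown here, three that share a sulfamate-bearing core have been tested in an assay on HEK293 cells for inhibition of Steryl-sulfatase (Homo sapiens), tested at 1 uM; a lower number here means a weaker effect, a higher number a stronger effect of the compound at the concentration tested. Compound 1 `CN(CCCN1CCCCC1)c1ccc(C(=O)N2CCc3ccc(OS(N)(=O)=O)cc3C2)cc1` gives 40.7%, the highest of the three numbers. Compound 3 `NS(=O)(=O)Oc1ccc2c(c1)CN(C(=O)c1cccc(N3CCN(c4ncccn4)CC3)c1)CC2` gives 24.4%, and compound 2 `CCN(Cc1ccccn1)c1cccc(C(=O)N2CCc3ccc(OS(N)(=O)=O)cc3C2)c1` gives 19.9%; both fall short of compound 1 by more than the usual scatter of repeated measurements.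

The next compound, compound 4 `CCCN(CCC)c1ccc(C(=O)N2CCc3ccc(OS(N)(=O)=O)cc3C2)cc1`, keeps the core of compound 1 and differs from it at a single position on the outer ring:

dipropylamino in place of methyl(3-(piperidin-1-yl)propyl)amino on an aromatic carbon

For the measured compounds named here, no measured pair in this set isolates this kind of exchange, so the direction has to be judged from the spread of the three numbers. The two compounds that carry a different amine arrangement than compound 1, compound 2 and compound 3, both sit well below it, which suggests that altering this part of the molecule tends to cost activity. The step from compound 1 to compound 4 is therefore expected to be a decrease, roughly a number 12.7 percentage points lower from compound 1 to compound 4 (beyond the scatter). For compound 4 in this assay, an inhibition near 28% is estimated, with a plausible range from 12% to 44%.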

Compound 4, a percentage reported as inhibition, at one concentration (the size of the read-out at that concentration, not a potency): 84.7%
Estimate against measurement, compound 4: 56.7 percentage points below; measured number above the stated range.
By their numbers in this assay, from the lowest: compounds 2 and 3 (each within the scatter of the next); then compound 1; then compound 4.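

In this assay, putting dipropylamino in place of methyl(3-(piperidin-1-yl)propyl)amino on this aromatic carbon, para to a large group, gives a number 44 percentage points higher from compound 1 to compound 4 (beyond the scatter). This single-place change shows that the position is highly sensitive to the choice of amine, and that a smaller substituent with no ring can be far better here than the longer piperidine-bearing tail. Nothing measured here explains why the number rises so sharply.

The exchange removes the piperidine ring and the second nitrogen and also changes the groups on the remaining nitrogen, so the compounds shown cannot say which of these differences matters. Diethylamino and dibutylamino at the same place would show how the number follows chain length, while a morpholine would test a ring attached directly to the aromatic carbon.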